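Azido on the core of compound 1: expected step

The compounds below may be only part of what the source reports. "The series", "measured", "known", "first", "only" and "open" are said of these compounds alone.

Compound 2 `N=c1sccn1Cc1ccc(Cl)nc1` gives 0.39 nM in an assay on M10 cells (Gallus gallus) for binding affinity to Neuronal acetylcholine receptor; alpha4/beta2 (Homo sapiens) (a lower number here means a stronger inhibitor, a higher number a weaker inhibitor), and compound 3 `[N-]=[N+]=Nc1cc(Cn2ccsc2=N)cnc1Cl` gives 0.47 nM. The step of a 1.2-fold higher number from compound 2 to compound 3 (0.08 log units; within the scatter) comes from azido in place of hydrogen on an aromatic carbon. Compound 1 `O=[N+]([O-])/C=C1\NC=CN1Cc1ccc(Cl)nc1` gives 60 nM in this assay, the highest of the three numbers; the difference between its core and the core of compound 2 is not broken down here. Compound 4 `[N-]=[N+]=Nc1cc(CN2C=CN/C2=C\[N+](=O)[O-])cnc1Cl` carries the same kind of change, (azido in place of hydrogen on an aromatic carbon); around the place the azido sits meta to a large group, where in compound 3 it sits meta to a group of 7 heavy atoms. Because the earlier step was a 1.2-fold higher number from compound 2 to compound 3 (0.08 log units; within the scatter), the step of a 1.2-fold higher number from compound 1 to compound 4 (0.07 log units; within the scatter) is expected to be of similar size. For compound 4 an estimate of 70 nM is therefore expected in this assay, between 30 nM and 160 nM.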

Compound 4, inhibition constant: 40 nM
The estimate for compound 4 lay 1.8-fold (0.24 log units) above the measured number; the measured number falls inside the stated range.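

In this assay, azido in place of hydrogen on an aromatic carbon gives a 1.5-fold lower number from compound 1 to compound 4 (0.18 log units; within the scatter), and this step agrees with the one on the other core: the same change on two cores in this assay, a 1.2-fold higher number (0.08 log units; within the scatter) from compound 2 to compound 3 and a 1.5-fold lower number (0.18 log units; within the scatter) from compound 1 to compound 4, 1.8-fold (0.26 log units) apart, within the scatter of two such steps

Across these two pairs the change carries from one core to the other with no step beyond the scatter, so azido can be placed on either core without a measurable shift in the number. For the compounds shown here, this rests on only two pairs in a single assay, and steps this small do not show whether azido shifts the number slightly or not at all, or that the same would hold on a third core.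

The compounds shown leave open whether a different group on the same aromatic carbon, such as an amine or a nitrile, would behave in the same way on both cores.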